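The source may report more compounds than this note shows. Statements on the series, on what has been measured and on what is new or still open speak of the compounds shown alone.

Measured compounds:
compound 1 `Cc1cccc(NC(=O)N[C@H](C)c2ccccc2)c1` — 98%
compound 2 `C[C@@H](NC(=O)Nc1ccc(C(C)(C)C)cc1)c1ccccc1` — 88%
compound 3 `C[C@H](NC(=O)Nc1ccc(C(C)(C)C)cc1)c1ccccc1` — 88%

In an ADME assay on the whole organism with Oryza sativa as the target, tested at 1 uM (a lower number here means a stronger effect, a higher number a weaker effect of the compound at the concentration tested), compound 2 gives 88%. It stands level with compound 3, whose value is 88%, and the gap to compound 1, with 98%, is within the scatter, so none of the three can be set apart from the others. Among the compounds with values here, the only step among measured compounds is no change at the digits printed from compound 2 to compound 3 (within the scatter), which is explained by the fact that compounds 2 and 3 differ only in the configuration as drawn; it says nothing about a change of substituent on the aromatic ring.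

Compound 4 `CCOC(=O)c1ccc(NC(=O)N[C@H](C)c2ccccc2)cc1` differs from compound 2 by ethoxycarbonyl in place of tert-butyl on an aromatic carbon. Within the data shown here, no measured step covers an exchange of this kind, so the expectation rests on the narrow spread of the three measured values alone. Compound 4 is therefore expected to stay close to compound 2, with a step of about a number 2 percentage points higher from compound 2 to compound 4 (within the scatter) that is not expected to exceed the scatter. The estimate for compound 4 in this assay is 90%, with a range from 70% to 100%.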

Compound 4, a percentage reported as activity, at one concentration (the size of the read-out at that concentration, not a potency): 100%
Compound 4: middle estimate off by 10 percentage points, on the low side; the measured number falls inside the stated range.
By their numbers in this assay, from the lowest: compounds 2, 3, 1 and 4 (each within the scatter of the next, the first and the last beyond it).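

In this assay, putting ethoxycarbonyl in place of tert-butyl on this aromatic carbon, para to a large group, gives a number 12 percentage points higher from compound 2 to compound 4 (beyond the scatter), a modest step and the only one so far that lies beyond the scatter. It shows that, unlike the change of configuration between compound 2 and compound 3, a change of group at this position can move the read-out, here towards a weaker effect at the concentration tested. Nothing at hand gives a cause for this step.

As far as these compounds go, whether a carboxylic acid, a primary amide or a methoxy group in the same place would read like compound 2 or like compound 4 stays open. Also open, from the compounds shown here alone, is whether the exchange would give a similar step in the opposite configuration at the stereocentre.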